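From compound 3 to compound 4: a methoxy added

The source may report more compounds than this note shows. Statements on the series, on what has been measured and on what is new or still open speak of the compounds shown alone.

Compound 1 `Cc1cc(NC(=O)Nc2cccc(C(N)=O)c2)c2ccccc2n1` gives > 25000 nM
Compound 2 `COc1ccc(NC(=O)Nc2cc(C)nc3ccccc23)cc1OC` gives > 25000 nM
Compound 3 `Cc1cc(NC(=O)Nc2cccc(F)c2)c2ccccc2n1` gives > 25000 nM

In an ADME assay on HepG2 cells (Homo sapiens) for cytotoxicity, with a stated time of 72 h (on this read-out lower numbers stand for an effect already at smaller amounts and higher numbers for an effect only at larger amounts of compound), compound 3 gives > 25000 nM as a limit of the assay and not a number, so its place among the others cannot be read. The series as a whole shows the limit of > 25000 nM in this assay, at which 3 of the 3 values shown sit, and nothing finer.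

Compound 4 `COc1ccc(NC(=O)Nc2cc(C)nc3ccccc23)cc1F` follows from compound 3 through methoxy in place of hydrogen on an aromatic carbon with methoxy in place of hydrogen on an aromatic carbon, ortho to a fluoro group and para to a large group.

For the measured compounds named here, the one measured step that bears on this is a step that the two limits leave unreadable from compound 1 to compound 3 and it offers no size to carry over. Compound 2 also carries methoxy and gives > 25000 nM as a limit too. No step beyond the scatter is therefore expected, and no direction can be named. The expected change is a number no higher from compound 3 to compound 4 (the limit leaves the size open) in this estimate, and another limit is the likeliest report. Compound 4 is estimated at 25000 nM with an expected range from 12000 nM to 50000 nM in this assay when it is measured.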

Compound 4, half-maximal effective concentration: > 25000 nM
Compound 4 ended at the assay's limit (the forecaster's own chance of this, stated with the estimate: 85%); the middle value sits exactly at the limit.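

In this assay, for the compounds shown here, compound 4 gives > 25000 nM, a limit of the assay and not a number, so no step from compound 3 or compound 2 to compound 4 can be read. The compounds shown leave open at what concentration any of them would give a measurable effect: the limit of > 25000 nM in this assay, at which 4 of the 4 values shown sit.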